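The source may report more compounds than this note shows. Statements on the series, on what has been measured and on what is new or still open speak of the compounds shown alone.

Compound 3 `Cc1ccc(CNc2ncnc3c2ncn3[C@@H]2O[C@H](CO)[C@@H](O)[C@H]2O)cc1` gives only a limit in a functional assay on K562 cells (Homo sapiens) for antiproliferative activity, with a stated time of 72 h (a lower number here means a stronger inhibitor, a higher number a weaker inhibitor), where compound 3 is reported as > 166000 nM and not as a number. Compound 1 `OC[C@H]1O[C@@H](n2cnc3c(NCc4ccccc4F)ncnc32)[C@H](O)[C@@H]1O` gives 33200 nM and compound 2 `OC[C@H]1O[C@@H](n2cnc3c(NCc4cccc(Br)c4)ncnc32)[C@H](O)[C@@H]1O` gives 19700 nM; between them a 1.7-fold lower number from compound 1 to compound 2 (0.23 log units; within the scatter). Against compound 3 the halogenated benzyl compounds stand apart: an at least 5.0-fold higher number from compound 1 to compound 3 (0.69 log units; beyond the scatter) and an at least 8.4-fold higher number from compound 2 to compound 3 (0.92 log units; beyond the scatter), both beyond the scatter, their full size open because of the limit of > 166000 nM in this assay, at which 1 of the 3 values shown sits. Compound 4 `OC[C@H]1O[C@@H](n2cnc3c(NCc4ccc(F)c(Cl)c4)ncnc32)[C@H](O)[C@@H]1O` carries 3-chloro-4-fluorophenyl in place of 4-methylphenyl on a saturated chain carbon bound to a nitrogen on an aromatic ring. Both measured steps into compound 3 bear on this change and run against 4-methylphenyl, so a return toward the range of compound 1 and compound 2 is expected. For compound 4 a step of an at least 6.6-fold lower number from compound 3 to compound 4 (0.82 log units; beyond the scatter) is expected. Compound 4 is estimated at 25000 nM, within 8000 nM to 90000 nM.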

Compound 4, half-maximal inhibitory concentration: 5500 nM
The estimate for compound 4 lay 4.5-fold (0.66 log units) above the measured number, outside the stated range (below it).
By their numbers in this assay, from the lowest: compound 4; then compounds 2 and 1 (each within the scatter of the next). At a limit, above all of these: compound 3.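

Going by these compounds alone, at this position, on a saturated chain carbon bound to a nitrogen on an aromatic ring, 3-chloro-4-fluorophenyl is the first group to separate from the other halogenated groups in this assay: a 3.6-fold lower number from compound 2 to compound 4 (0.55 log units; beyond the scatter) and a 6.0-fold lower number from compound 1 to compound 4 (0.78 log units; beyond the scatter). Against 4-methylphenyl, the change gives an at least 30-fold lower number from compound 3 to compound 4 (1.47 log units; beyond the scatter). The full size of that step stays open, as compound 3 gives only a limit: the limit of > 166000 nM in this assay, at which 1 of the 4 values shown sits.

On these data alone, whether 3-chlorophenyl or 4-fluorophenyl alone would match 3-chloro-4-fluorophenyl stays open. So does the outcome of placing a carboxylic acid or an amine on the phenyl ring.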